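A hydroxy group added to the linker carbon

This account rests on a few compounds, and the source may have more. Where it says the series, first, only, none or still open, it means among the compounds named here.

Three compounds have been measured in a functional assay on HEK293 cells for agonist activity at G-protein coupled receptor 52 (Homo sapiens), read by cAMP accumulation, with a stated time of 15 min; on this read-out higher numbers stand for larger maximal responses and lower numbers for smaller maximal responses:

compound 1, `O=C(NCCO)c1cccc2c1CCN2c1cc(Cc2cc(F)cc(C(F)(F)F)c2)ncn1`, gives 136% in this assay
compound 2, `O=C(NCCO)c1cccc2c1CCN2c1nccc(Cc2cc(F)cc(C(F)(F)F)c2)n1`, gives 138% in this assay
compound 3, `O=C(NCCO)c1cccc2c1CCN2c1nccc(C(O)c2cc(F)cc(C(F)(F)F)c2)n1`, gives 130% in this assay

Compound 1 and compound 2 are built from the same atoms joined differently; the difference between the two cores is not broken down here, and their two values lie within the scatter of each other. Compound 3 is compound 2 with a single change, (hydroxy in place of hydrogen on a saturated chain carbon bound to two aromatic carbons), which gave a number 8 percentage points lower from compound 2 to compound 3 (within the scatter). The not yet measured compound 4, `O=C(NCCO)c1cccc2c1CCN2c1cc(C(O)c2cc(F)cc(C(F)(F)F)c2)ncn1`, carries the same change made on the core of compound 1: hydroxy in place of hydrogen on a saturated chain carbon bound to two aromatic carbons. The place of the change is the same in both pairs. On compound 2 the change gave a number 8 percentage points lower from compound 2 to compound 3 (within the scatter), a step that stays inside the usual scatter. A step of the same small size is expected here, a number 8 percentage points lower from compound 1 to compound 4 (within the scatter). Compound 4 is therefore expected to reach about 128% in this assay, most likely between 112% and 144%.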

Compound 4, largest response reached (Emax), in percent of the reference or control that the assay uses: 134%
Compound 4: the middle estimate sits 6 percentage points below what was measured, within the range that was stated.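

In this assay, putting hydroxy in place of hydrogen on the saturated chain carbon bound to two aromatic carbons gave a number 2 percentage points lower from compound 1 to compound 4 (within the scatter). Set beside the earlier step, the same change looks alike on the two cores, with no difference that can be told apart from the usual scatter: the same change on two cores in this assay, a number 8 percentage points lower (within the scatter) from compound 2 to compound 3 and a number 2 percentage points lower (within the scatter) from compound 1 to compound 4, 6 percentage points apart, within the scatter of two such steps. Among the compounds shown here, for the largest response, then, this change carries over between these two cores and has no effect that can be told from scatter on either one, but the finding rests on only two pairs, says nothing about any other core, and covers only the maximal response, not how much compound is needed to reach it.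

The compounds shown leave open whether another group on that same chain carbon, such as an amine, a methoxy group or a fluorine atom, would be tolerated as well. They also leave open what a carbonyl in place of that carbon would do on either core.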